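The source may hold more compounds than are shown below. What is called first, only, known or untested is meant among the compounds shown, and "the series" means these compounds.

Within the data shown here, compound 1 `ClCc1cccc(Cn2cnc3c(Cl)nc(Cl)nc32)c1` stands at the low end of the numbers so far gathered in a functional assay on SNB-75 cells (Homo sapiens) for cytotoxicity, read by sulforhodamine B assay, with a stated time of 48 h (a lower number here means a stronger inhibitor of growth, a higher number a weaker inhibitor of growth), where compound 1 gives 3890 nM, the lowest of the two numbers available. Compound 2 `Nc1nc(Cl)c2ncn(Cc3ccc(CCl)cc3)c2n1` gives 91200 nM in this assay, a higher number than that of compound 1, and the gap between the two lies well beyond the usual scatter of the measurement. Compound 3 `ClCc1ccc(Cn2cnc3ncnc(Cl)c32)cc1` was also part of the study, but in this assay compound 3 gives "not determined" (no result reported), no result having been reported for it.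

Compound 4 `ClCc1cccc(Cn2cnc3c(Cl)ncnc32)c1` has not yet been measured. It differs from compound 1 in a single place: hydrogen in place of chloro on an aromatic carbon. Among the measured compounds shown here, no pair of measured compounds in this set is separated by exactly this change, so there is no directly comparable step to lean on. For the measured compounds named here, the only hint comes from compound 2, whose core differs from that of compound 1 at more than one point. In this assay compound 2 gives 91200 nM, a much higher number. On that slender basis, compound 4 is expected to show a step upward from compound 1 of about a 3.1-fold higher number from compound 1 to compound 4 (0.49 log units; beyond the scatter), beyond the scatter. The estimated value for compound 4 in this assay is 12000 nM, with a likely range from 3500 nM to 40000 nM.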

Compound 4, concentration for total growth inhibition: 4570 nM
Compound 4: the middle estimate sits 2.6-fold (0.42 log units) above what was measured; low and high end bracket the measured number.
By their numbers in this assay, from the lowest: compounds 1 and 4 (each within the scatter of the next); then compound 2.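

In this assay, hydrogen in place of chloro on the aromatic carbon between two ring nitrogen atoms gives a 1.2-fold higher number from compound 1 to compound 4 (0.07 log units; within the scatter), so the two compounds cannot be told apart in this read-out. Among these compounds, this is the only step in the set that isolates a single place, and it shows that at this position, on the six-membered aromatic ring with 2 nitrogen, chloro and hydrogen give values within the scatter of each other, so this chloro group is not needed to keep the number seen for compound 1. Nothing measured here accounts for this result.

Going by these compounds, whether other groups at this same carbon would also leave the number in place remains open, for instance an amine, a methoxy group or a longer alkyl chain. Also open, on these data alone, is whether the remaining chloro group on the same ring, which compound 4 keeps, could be replaced by hydrogen or an amine with as little consequence.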